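Swapping the Side Group on a Short-Lived Core

A few compounds are considered here, and "the series" means these few. Any claim that something is new, unique, unknown or untested is made for them only; others in the source may bear on it.

Measured compounds:
- Compound 1 `CC(C)C(c1ncc[nH]1)c1ccc(-c2ccc3cccc(F)c3c2)[nH]c1=O`: in an ADME assay on microsomes from liver (Mus musculus) for metabolic stability (on this read-out higher numbers stand for a longer-lived compound and lower numbers for a shorter-lived compound), compound 1 gives only a limit, < 0.0667 h, not a number.
- Compound 2 `CC(C)C(Nc1nccs1)c1ccc(-c2ccc3cccc(F)c3c2)[nH]c1=O`: in this assay compound 2 gives 0.0733 h.

Compound 2 therefore holds the only number shown; the other value is a limit (the limit of < 0.0667 h in this assay, at which 1 of the 2 values shown sits). Within the data shown here, the one measured step, an at least 1.0-fold higher number from compound 1 to compound 2 (0.04 log units; that floor lies within the scatter), changed the same place that is changed here and stayed within the scatter.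

Compound 3 `CC(C)C(Cc1nnc[nH]1)c1ccc(-c2ccc3cccc(F)c3c2)[nH]c1=O` differs from compound 2 by (4H-1,2,4-triazol-3-yl)methyl in place of (1,3-thiazol-2-yl)amino on a saturated chain carbon bound to an aromatic carbon and a saturated chain carbon. Among the measured compounds shown here, no measured step covers this particular change, so the expectation rests on the shared core, which in both measured compounds is short-lived in this assay. Compound 3 is expected to stay close to compound 2, with a step of a 1.0-fold lower number from compound 2 to compound 3 (0.02 log units; within the scatter), no larger than the scatter. The estimate for compound 3 is 0.07 h, ranging from 0.035 h to 0.15 h.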

Compound 3, half-life: < 0.0667 h
Compound 3: no number, only a limit (the forecaster's own chance of this, stated with the estimate: 40%); at least 1.0-fold (0.02 log units) between middle value and limit.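

In this assay, putting (4H-1,2,4-triazol-3-yl)methyl in place of (1,3-thiazol-2-yl)amino on this saturated chain carbon gives an at least 1.0-fold lower number from compound 2 to compound 3 (0.04 log units; that floor lies within the scatter). That figure is only a floor, so the true gap could be larger, and nothing printed shows this change to matter beyond the scatter. What is new is that a second side group, this one with a five-membered aromatic ring holding 3 hetero atoms, also ends at a limit rather than a number: the limit of < 0.0667 h in this assay, at which 2 of the 3 values shown sit.

Compound 1 and compound 3 both give limits, so the step between them cannot be read. Still open, from the compounds shown here alone, is whether any other group at this place, such as a carboxylic acid or a longer chain, would give a number clearly separated from that of compound 2.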